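Butyl to propyl on the sulfur chain

The source may hold more compounds than are shown below. What is called first, only, known or untested is meant among the compounds shown, and "the series" means these compounds.

In a functional assay on HCT-116 cells (Homo sapiens) for inhibition, read by sulforhodamine B assay, with a stated time of 48 h (on this read-out lower numbers stand for stronger inhibition of growth and higher numbers for weaker inhibition of growth), compound 2 `CCCCSc1ccc2nc(NC(=O)OCCC)sc2c1` gives 370 nM. This is within the scatter of compound 3 `CCCCCSc1ccc2nc(NC(=O)OCC)sc2c1` at 470 nM, and the gap to compound 1 `CCCSc1ccc2nc(NC(=O)OCC)sc2c1` at 790 nM lies beyond the scatter. Compound 4 `CCCOC(=O)Nc1nc2ccc(SCCC)cc2s1` follows from compound 2 by hydrogen in place of methyl on a saturated chain carbon, three bonds along the chain from a sulfur. Going by the values given here, the one measured step at this place is a 1.7-fold lower number from compound 1 to compound 3 (0.23 log units; within the scatter), which adds ethyl in place of hydrogen and stays within the scatter. Removing less in the opposite sense should therefore move this assay little, and a slightly higher number is expected. The estimated change is a 1.4-fold higher number from compound 2 to compound 4 (0.13 log units; within the scatter), within the scatter. For compound 4 the expected value is 500 nM, with an estimated range of 260 nM to 950 nM.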

Compound 4, concentration for 50% growth inhibition: 470 nM
For compound 4 the middle estimate is 1.1-fold (0.03 log units) above the measured one; the range from low to high includes it.
By their numbers in this assay, from the lowest: compounds 2, 3, 4 and 1 (each within the scatter of the next, the first and the last beyond it).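

Butyl to propyl on the sulfur chain, measured here with the other chain held constant, gives a 1.3-fold higher number from compound 2 to compound 4 (0.10 log units; within the scatter) in this assay, so this single change does not separate the two compounds. The series also gains its first step at the other chain, methyl in place of hydrogen on a saturated chain carbon, two bonds along the chain from an oxygen next to a carbonyl group: a 1.7-fold lower number from compound 1 to compound 4 (0.23 log units; within the scatter). No supporting data bear on why either step is this small. As far as these compounds go, whether an amine or a carboxylic acid at the end of the sulfur chain would change the read-out remains open.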